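Swapping the aryl group on the hydrazone of an aryl sulfonamide

The source may report more compounds than this note shows. Statements on the series, on what has been measured and on what is new or still open speak of the compounds shown alone.

Measured compounds:
- compound 1, `C/C(=N\NC(=O)c1cccc(S(=O)(=O)N2CCOCC2)c1)c1ccc(F)cc1`: > 100000 nM
- compound 2, `C/C(=N\NC(=O)c1cccc(S(=O)(=O)N2CCOCC2)c1)c1ccccc1O`: 1370 nM
- compound 3, `C/C(=N\NC(=O)c1cccc(S(=O)(=O)N2CCOCC2)c1)c1cc(Br)ccc1O`: 2410 nM

In a functional assay on SMMC-7721 cells (Homo sapiens) for antiproliferative activity, read by MTT assay, with a stated time of 72 h (on this read-out higher numbers stand for weaker inhibition and lower numbers for stronger inhibition), compound 1 gives > 100000 nM, which is a limit of the assay and not a number. Compound 2 gives 1370 nM in this assay, and compound 3 gives 2410 nM. Among the two actual numbers compound 3 holds the higher one, though the gap to compound 2 is small: a 1.8-fold higher number from compound 2 to compound 3 (0.25 log units; within the scatter). The two large steps, an at least 72-fold lower number from compound 1 to compound 2 (1.86 log units; beyond the scatter) and an at least 41-fold lower number from compound 1 to compound 3 (1.61 log units; beyond the scatter), show that the 2-hydroxyphenyl group carries most of the activity.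

Compound 4, `C/C(=N\NC(=O)c1cccc(S(=O)(=O)N2CCOCC2)c1)c1cccc(N)c1O`, has not been measured. It differs from compound 3 in one place: 3-amino-2-hydroxyphenyl in place of 5-bromo-2-hydroxyphenyl on a carbon with a double bond to nitrogen. The 2-hydroxy group is kept, the bromo is dropped, and an amino group enters. Since the bromo made little difference in the step from compound 2 to compound 3, compound 4 is expected to land close to compound 2, with a 1.6-fold lower number from compound 3 to compound 4 (0.21 log units; within the scatter) a modest change at most. Compound 4 is therefore estimated at 1500 nM, with a range from 400 nM to 6000 nM.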

Compound 4, half-maximal inhibitory concentration: 2330 nM
Beside the measured number, compound 4's estimate is 1.6-fold (0.19 log units) below it; the range from low to high includes it.
By their numbers in this assay, from the lowest: compounds 2, 4 and 3 (each within the scatter of the next). At a limit, above all of these: compound 1.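

In this assay, the ring on the carbon with a double bond to nitrogen accepts an amino group as readily as a bromo: adding the amino group gives a 1.7-fold higher number from compound 2 to compound 4 (0.23 log units; within the scatter), and exchanging the bromo-bearing ring for the amino-bearing one gives a 1.0-fold lower number from compound 3 to compound 4 (0.01 log units; within the scatter). Two quite different additions to the 2-hydroxyphenyl group therefore leave the number within the scatter, and the gap to the 4-fluorophenyl compound holds for this third member too, with an at least 42-fold lower number from compound 1 to compound 4 (1.63 log units; beyond the scatter). That gap is measured against a limit and not a number, the one compound 1 gives: the limit of > 100000 nM in this assay, at which 1 of the 4 values shown sits.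

Still open, from the compounds shown here alone, is what a methoxy group in place of the hydroxy would give, which would test that hydroxy group directly. So is the effect of a carboxylic acid in place of the amino group, or of a longer chain on that ring.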